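The source may hold more compounds than are shown below. What is called first, only, known or untested is meant among the compounds shown, and "the series" means these compounds.

Measured compounds:
compound 1, `Cn1cc(-c2cnc(N)c(Oc3ccc(C(=O)Nc4cccc(Cl)c4)cc3)n2)cn1`, 21200 nM
compound 2, `Cn1cc(-c2cnc(N)c(Oc3ccc(C(=O)Nc4ccc(Cl)cn4)cc3)n2)cn1`, 24200 nM

Both numbers come from a functional assay on HepG2 cells (Homo sapiens) for inhibition, read by MTT assay, with a stated time of 72 h; a lower number here means a stronger inhibitor, a higher number a weaker inhibitor. Compound 1, with `Cn1cc(-c2cnc(N)c(Oc3ccc(C(=O)Nc4cccc(Cl)c4)cc3)n2)cn1`, gives 21200 nM in this assay, and compound 2, with `Cn1cc(-c2cnc(N)c(Oc3ccc(C(=O)Nc4ccc(Cl)cn4)cc3)n2)cn1`, gives 24200 nM. The two values lie within the scatter of each other, the step being a 1.1-fold higher number from compound 1 to compound 2 (0.06 log units; within the scatter). Within the data shown here, compound 2 therefore stands among only two measured numbers, and the nearest of them, compound 1, is not separated from it beyond the scatter.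

Compound 3, `Cn1cc(-c2cnc(N)c(Oc3ccc(C(=O)Nc4ncccc4Cl)cc3)n2)cn1`, differs from compound 2 in one place: 3-chloropyridin-2-yl in place of 5-chloropyridin-2-yl on an amide-type nitrogen. Among the measured compounds shown here, the only measured step that bears on this change is the one from compound 1 to compound 2, which also exchanged the aryl group on the amide-type nitrogen and gave a 1.1-fold higher number from compound 1 to compound 2 (0.06 log units; within the scatter), a step within the scatter. On that basis no step beyond the scatter is expected in this assay for compound 3. Compound 3 is thus expected to show a step of a 1.0-fold lower number from compound 2 to compound 3 (0.00 log units; within the scatter). Compound 3 is estimated at 24000 nM, with a range from 9000 nM to 60000 nM.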

Compound 3, half-maximal inhibitory concentration: 21700 nM
For compound 3 the middle estimate is 1.1-fold (0.04 log units) above the measured one, within the range that was stated.
By their numbers in this assay, from the lowest: compounds 1, 3 and 2 (each within the scatter of the next).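

Compound 2 and compound 3 have the same atoms joined differently, and in this assay exchanging 5-chloropyridin-2-yl for 3-chloropyridin-2-yl on the amide-type nitrogen gives a 1.1-fold lower number from compound 2 to compound 3 (0.05 log units; within the scatter). Among these compounds, this is the first measured exchange between two chloropyridinyl groups at this position, and it shows that this difference in how the atoms are joined does not separate the two compounds beyond the scatter. The comparison with the chlorophenyl compound gives the same outcome, with a 1.0-fold higher number from compound 1 to compound 3 (0.01 log units; within the scatter), so all three aryl groups at this position now lie within the scatter of one another, though nothing measured here bears on why the numbers stay together.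

The compounds shown leave open whether any group on the amide-type nitrogen would move the number in this assay beyond the scatter, for example a pyridinyl ring carrying an amine or a carboxylic acid in place of the chlorine, or a longer alkyl chain in place of the ring. They also leave open whether the three compounds would stay this close together in any other test, or with a change elsewhere in the shared core.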